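Methyl to Hydrogen on the Chain: Compound 2 to Compound 3

A few compounds are considered here, and "the series" means these few. Any claim that something is new, unique, unknown or untested is made for them only; others in the source may bear on it.

compound 1 `COc1cccc(N2CCN(C(=O)C(C)N3C(=O)CCC3=O)CC2)c1` — 0%
compound 2 `CCC(C(=O)N1CCN(c2cccc(C(F)(F)F)c2)CC1)N1C(=O)CCC1=O` — 100%

In a functional assay on the whole organism (strain Swiss) with Mus musculus as the target, in the maximal electroshock model, with a stated time of 1 h, at a dose of 300 mg/kg by the intraperitoneal route (on this read-out lower numbers stand for a weaker effect and higher numbers for a stronger effect at the one dose given), compound 2 gives 100%, the higher of the two numbers measured. Going by the values given here, compound 1 lies far below it in this assay, a gap beyond the usual scatter, but compound 1 differs from compound 2 both in the chain and in the group on the aryl ring, so no single measured step isolates either change. Compound 3 `CC(C(=O)N1CCN(c2cccc(C(F)(F)F)c2)CC1)N1C(=O)CCC1=O` differs from compound 2 in one place: hydrogen in place of methyl on a saturated chain carbon, two bonds along the chain from an amide-type nitrogen in a ring and a carbonyl carbon. Because compound 2 gives 100% while compound 1, carrying the shorter chain among its two differences, gives 0%, a drop is expected, though its size is uncertain. The step from compound 2 to compound 3 in this assay is expected to be a decrease beyond the scatter, a number 40 percentage points lower from compound 2 to compound 3 (beyond the scatter). Compound 3 is therefore estimated to give 60% in this assay, in the range 20% to 100%.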

Compound 3, a percentage reported as activity, at one dose (the size of the read-out at that dose, not a potency): 100%
Compound 3: the middle estimate sits 40 percentage points below what was measured; measured number inside the range.
By their numbers in this assay, from the lowest: compound 1; then compounds 2 and 3 (each within the scatter of the next).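

In this assay, hydrogen in place of methyl on this saturated chain carbon, which reads equally as ethyl to methyl, gives no change at the digits printed from compound 2 to compound 3 (within the scatter), so the earlier gap cannot be assigned to this chain change at the one dose given. Trifluoromethyl in place of methoxy on an aromatic carbon gives a number 100 percentage points higher from compound 1 to compound 3 (beyond the scatter), which isolates the aryl group as a single-place change on the methyl-bearing chain, a comparison the earlier pair could not make. Nothing measured here accounts for either step.

On these data alone, what remains open is whether a longer chain, such as propyl, is accepted at this chain carbon, and whether chlorine could stand in place of trifluoromethyl on the aromatic carbon. Methoxy on the aromatic carbon also remains untested here in combination with the ethyl chain, and a read-out at one dose does not compare the potency of compound 2 and compound 3.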